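A few compounds are considered here, and "the series" means these few. Any claim that something is new, unique, unknown or untested is made for them only; others in the source may bear on it.

In a functional assay on IMR-32 cells (Homo sapiens) for antiproliferative activity, read by sulforhodamine B assay, with a stated time of 48 h (on this read-out higher numbers stand for weaker inhibition of growth and lower numbers for stronger inhibition of growth), compound 1 `O=C1COc2ccccc2N1CCCn1cc(-c2cccnc2)nn1` gives 860 nM and compound 2 `O=C1COc2ccccc2N1CCCn1cc(CO)nn1` gives 5500 nM. Compound 2 therefore holds the higher of the two numbers and is the weaker growth inhibitor of the pair. Compound 3 `CCCc1cn(CCCN2C(=O)COc3ccccc32)nn1` keeps the core of compound 2 and changes only the group that compound 2 carries on its aromatic carbon: ethyl in place of hydroxy on a saturated chain carbon bound to an aromatic carbon. Put another way, this is hydroxymethyl to propyl. Among the compounds with values here, only one measured step bears on this change, a 6.4-fold higher number from compound 1 to compound 2 (0.81 log units; beyond the scatter), a modest step made at the same place on the molecule. Within the data shown here, no measured compound carries a propyl group, so that step gives a rough size but no firm direction. Among the measured compounds shown here, compound 2 sits at the top of the measured range with 5500 nM, so a modest move toward a lower number in this assay is expected, smaller than the one measured step. The estimated change is a 2.3-fold lower number from compound 2 to compound 3 (0.36 log units; beyond the scatter). For compound 3 the expected value is 2400 nM, with an estimated range from 800 nM to 7500 nM.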

Compound 3, concentration for 50% growth inhibition: 1400 nM
Estimate against measurement, compound 3: 1.7-fold (0.23 log units) above; measured number inside the range.
By their numbers in this assay, from the lowest: compounds 1 and 3 (each within the scatter of the next); then compound 2.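

In this assay, the step from hydroxy to ethyl on a saturated chain carbon bound to an aromatic carbon, which is hydroxymethyl to propyl, gives a 3.9-fold lower number from compound 2 to compound 3 (0.59 log units; beyond the scatter) and shows that this position also responds to a change between two open-chain groups, where the earlier step had set hydroxymethyl only against pyridin-3-yl. The other comparison, a 1.6-fold higher number from compound 1 to compound 3 (0.21 log units; within the scatter), shows that propyl and pyridin-3-yl cannot be told apart in this assay, so among these three compounds an aromatic ring at this place is not required to stay clear of the number held by compound 2. No measurement offered here gives a reason for either step.

The compounds shown leave open whether a methoxymethyl group, which keeps the oxygen but loses the hydroxy hydrogen, would stand with compound 2 or with compound 3. They also leave open whether a longer chain such as pentyl, or an aminomethyl group or a carboxylic acid at the same place, would follow propyl or hydroxymethyl.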